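Swapping the carboxy of compound 1 for methylsulfonyl

The source may report more compounds than this note shows. Statements on the series, on what has been measured and on what is new or still open speak of the compounds shown alone.

Compound 1 `CCC(CSC(CCc1ccccc1C(=O)O)c1cccc(OCc2ccc3ccc(Cl)cc3n2)c1)C(=O)O` is measured in an assay on membranes from lung for binding affinity to cysteinyl leukotriene receptor 1 (Cavia porcellus) (a lower number here means a stronger inhibitor, a higher number a weaker inhibitor), and gives 1 nM. Among the three measured compounds it holds the second highest number: compound 3 `CS(=O)(=O)Nc1ccccc1CCC(SCCC(=O)O)c1cccc(OCc2ccc3ccc(Cl)cc3n2)c1` gives 0.6 nM, which lies within the scatter of compound 1, while compound 2 `CCC(CSC(CCc1ccccc1C(=O)NS(=O)(=O)c1ccccc1C)c1cccc(OCc2ccc3ccc(Cl)cc3n2)c1)C(=O)O` gives 6.5 nM, a number beyond the scatter. Compound 4 `CCC(CSC(CCc1ccccc1S(C)(=O)=O)c1cccc(OCc2ccc3ccc(Cl)cc3n2)c1)C(=O)O` differs from compound 1 in one place: methylsulfonyl in place of carboxy on an aromatic carbon.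

Going by the values given here, one measured step bears directly on this change. Replacing the same carboxy of compound 1 with a ((2-methylphenyl)sulfonyl)amino group gave a 6.5-fold higher number from compound 1 to compound 2 (0.81 log units; beyond the scatter), a modest weakening. Compound 3 carries a methanesulfonamido group on its aromatic ring in place of a carboxy, but its core also differs elsewhere, so its number alone cannot be read as a step from compound 1. The carboxy of compound 1 has so far not been replaced without a loss, and the methylsulfonyl removes it entirely. For compound 4 the expectation is therefore a step of a 20-fold higher number from compound 1 to compound 4 (1.30 log units; beyond the scatter) toward a weaker binder, beyond the scatter, with an estimated value of 20 nM and a range from 4 nM to 100 nM.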

Compound 4, half-maximal inhibitory concentration: 1 nM
Estimate against measurement, compound 4: 20-fold (1.30 log units) above; measured number outside the range, below it.
By their numbers in this assay, from the lowest: compounds 3, 1 and 4 (each within the scatter of the next); then compound 2.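

In this assay, putting methylsulfonyl on this aromatic carbon gives no change at the digits printed from compound 1 to compound 4 (within the scatter) and takes away the hydrogen-bond donor of the carboxy, so at this position the carboxy can be replaced with no loss in this read-out. Set beside a 6.5-fold higher number from compound 1 to compound 2 (0.81 log units; beyond the scatter) for the ((2-methylphenyl)sulfonyl)amino group, this shows that losing the carboxy does not by itself weaken the number and that the outcome depends on which group enters. Nothing measured here explains why the two replacements differ.

The compounds shown leave open how an amine or a primary amide would fare on this same aromatic carbon. They also leave open whether a longer chain ending in methylsulfonyl would hold the number of compound 4.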